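The source may report more compounds than this note shows. Statements on the series, on what has been measured and on what is new or still open speak of the compounds shown alone.

- Compound 1 `FC(F)(F)c1ccc(-c2nn(-c3ccccc3)cc2CNc2ccc(Cl)cc2)cc1`: 10000 nM
- Compound 2 `FC(F)(F)c1ccc(NCc2cn(-c3ccccc3)nc2-c2ccc(C(F)(F)F)cc2)cc1`: 26000 nM

In an ADME assay on Vero 76 cells (Chlorocebus sabaeus) for cytotoxicity, read by MTT assay, with a stated time of 96 h (a lower number here means that less compound is tolerated, a higher number that more compound is tolerated), compound 1, at 10000 nM, holds the lower of the two numbers. Compound 3 `Cc1ccc(-c2nn(-c3ccccc3)cc2CNc2ccc(Cl)cc2)cc1` has methyl in place of trifluoromethyl on an aromatic carbon, para to a large group: methyl in place of trifluoromethyl on an aromatic carbon. Among the measured compounds shown here, the only measured step, a 2.6-fold higher number from compound 1 to compound 2 (0.41 log units; beyond the scatter), is modest and swaps chloro at a different place, so it bears on this change only loosely. No step beyond the scatter is therefore expected, and the estimated size is a 1.2-fold higher number from compound 1 to compound 3 (0.08 log units; within the scatter). For compound 3 the expected value is 12000 nM, with an estimated range of 5000 nM to 30000 nM.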

Compound 3, half-maximal cytotoxic concentration: > 100000 nM
Compound 3 was reported as a limit (the forecaster's own chance of this, stated with the estimate: 5%); at least 8.3-fold (0.92 log units) between middle value and limit.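

Cytotoxicity in this assay depends not only on the chloro place: at the aromatic carbon para to a large group, methyl in place of trifluoromethyl gives an at least 10-fold higher number from compound 1 to compound 3 (1.00 log units; beyond the scatter). Compound 3 gives > 100000 nM, which is a limit of the assay and not a number. The size of this step therefore rests on a limit: the limit of > 100000 nM in this assay, at which 1 of the 3 values shown sits.

On these data alone, whether the same change holds with trifluoromethyl in place of chloro, as in compound 2, remains open. Also open, as far as these compounds go, is how an amine, a methoxy group or a longer chain at this position would read.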